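Trimethoxyphenyl variant of compound 1 in the cell assay

A few compounds are considered here, and "the series" means these few. Any claim that something is new, unique, unknown or untested is made for them only; others in the source may bear on it.

Three compounds of the series have numbers in an ADME assay on HEK293 cells (Homo sapiens) for antiproliferative activity, read by MTT assay, with a stated time of 24 h; on this read-out lower numbers stand for stronger inhibition and higher numbers for weaker inhibition. Compound 1 `COc1ccc(-c2cc(/C=C/C(=O)c3ccc(OC)c(OC)c3)nc3cc(-c4ccccc4)nn23)cc1` gives 48500 nM and sits second highest of the three; compound 3 `COc1ccc(-c2cc(/C=C/C(=O)c3ccccc3)nc3cc(-c4ccccc4)nn23)cc1` gives 53200 nM, and compound 2 `COc1ccc(C(=O)/C=C/c2cc(-c3ccc(OC)cc3)n3nc(-c4ccccc4)cc3n2)cc1` gives 36100 nM. All three lie within the scatter of one another: a 1.3-fold lower number from compound 1 to compound 2 (0.13 log units; within the scatter), a 1.1-fold higher number from compound 1 to compound 3 (0.04 log units; within the scatter), a 1.5-fold higher number from compound 2 to compound 3 (0.17 log units; within the scatter).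

Compound 4 `COc1ccc(C(=O)/C=C/c2cc(-c3cc(OC)c(OC)c(OC)c3)n3nc(-c4ccccc4)cc3n2)cc1OC` is the next member. Relative to compound 1 the change is 3,4,5-trimethoxyphenyl in place of 4-methoxyphenyl on an aromatic carbon. For the measured compounds named here, none of the measured steps touches this position: the step from compound 1 to compound 2 and the one from compound 2 to compound 3 remove a methoxy from the aryl ketone side, and the step from compound 1 to compound 3 swaps the whole aryl ketone, and each of them stays within the scatter. The series so far has therefore shown no movement on adding or removing methoxy groups, and there is no measured comparison for the aryl group attached to the core. On that basis no step beyond the scatter is expected in this assay from compound 1 to compound 4, which is to say an estimated 1.1-fold lower number from compound 1 to compound 4 (0.03 log units; within the scatter). Compound 4 is accordingly expected to give about 45000 nM, with a range from 18000 nM to 110000 nM.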

Compound 4, half-maximal inhibitory concentration: 81700 nM
Beside the measured number, compound 4's estimate is 1.8-fold (0.26 log units) below it; the range from low to high includes it.
By their numbers in this assay, from the lowest: compounds 2, 1, 3 and 4 (each within the scatter of the next, the first and the last beyond it).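

In this assay, for the compounds shown here, the change at the aryl group on the shared core, 3,4,5-trimethoxyphenyl in place of 4-methoxyphenyl, gives a 1.7-fold higher number from compound 1 to compound 4 (0.23 log units; within the scatter), the first reading at this position, since the earlier steps all fell on the aryl ketone side. This aromatic carbon, next to the ring nitrogen, therefore carries the larger group, with 12 heavy atoms instead of 8 and 3 hydrogen-bond acceptors instead of 1, without a step beyond the scatter in this read-out. Nothing available bears on the reason for this result.

On these data alone, both aryl groups compared at this position carry methoxy groups, and the comparison rests on a single pair sharing the 3,4-dimethoxyphenyl ketone, so it remains open whether the same holds with the phenyl ketone of compound 3 or the 4-methoxyphenyl ketone of compound 2. As far as these compounds go, it also remains open how this assay would respond to an aryl group bearing an amine or a carboxylic acid at this position, or to a saturated ring such as morpholine there.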